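Methyl for Chloro on the Pendant Ring of Compound 3

The compounds below may be only part of what the source reports. "The series", "measured", "known", "first", "only" and "open" are said of these compounds alone.

Measured compounds in a functional assay on IGROV-1 cells (Homo sapiens) for inhibition, read by sulforhodamine B assay, with a stated time of 48 h; a higher number here means a weaker inhibitor of growth, a lower number a stronger inhibitor of growth:
compound 1 `N#Cc1c(-c2nnc(O)c3nn(-c4ccc(Cl)cc4)cc23)nn(-c2ccccc2)c1-c1ccccc1` — 91300 nM
compound 2 `N#Cc1c(-c2nnc(-c3ccccc3)c3nn(-c4ccccc4)cc23)nn(-c2ccccc2)c1-c1ccccc1` — 94800 nM
compound 3 `N#Cc1c(-c2nnc(-c3ccccc3)c3nn(-c4ccc(Cl)cc4)cc23)nn(-c2ccccc2)c1-c1ccccc1` — 93400 nM

Compound 3 stands among three numbers that all lie within the scatter of one another: the step of a 1.0-fold higher number from compound 1 to compound 3 (0.01 log units; within the scatter) and the step of a 1.0-fold lower number from compound 2 to compound 3 (0.01 log units; within the scatter) each amount to no change beyond the noise. The phenyl in place of hydroxy and the chloro in place of hydrogen left the growth inhibition where it was.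

Compound 4 `Cc1ccc(-n2cc3c(-c4nn(-c5ccccc5)c(-c5ccccc5)c4C#N)nnc(-c4ccccc4)c3n2)cc1` differs from compound 3 in one place: methyl in place of chloro on an aromatic carbon. The step that bears most directly on it is the one in which chloro entered this same position, a 1.0-fold lower number from compound 2 to compound 3 (0.01 log units; within the scatter), which was within the scatter. Within the data shown here, no measured step shows what methyl does at that position, so the expectation rests on that single neighbour and on the flatness of the whole series.

Compound 4 is therefore expected to give a number in this assay that is not separated from compound 3 by more than the scatter, with an expected step of a 1.0-fold lower number from compound 3 to compound 4 (0.00 log units; within the scatter). The estimate for compound 4 is 93000 nM, with a range from 60000 nM to 145000 nM.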

Compound 4, concentration for 50% growth inhibition: 93400 nM
Compound 4: the middle estimate sits 1.0-fold (0.00 log units) below what was measured; low and high end bracket the measured number.
By their numbers in this assay, from the lowest: compounds 1, 3, 4 and 2 (each within the scatter of the next).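

In this assay, putting methyl in place of chloro on this aromatic carbon, para to a large group, gave no change at the digits printed from compound 3 to compound 4 (within the scatter), so 4-chlorophenyl and 4-methylphenyl cannot be told apart in this read-out. Methyl also proved no different from hydrogen at the same place (a 1.0-fold lower number from compound 2 to compound 4 (0.01 log units; within the scatter)), which means that compound 2, compound 3 and compound 4 now show three substituents at this position with no step beyond the scatter, and none of the compounds shown goes against this. Nothing given here explains why the position is so flat.

As far as these compounds go, it remains open whether a group of another kind at this position, such as an amine, a carboxylic acid or a longer chain, would move the number beyond the scatter. Also unsettled is whether changes to the phenyl groups that all four compounds share would separate any of them in this assay, as every step shown so far lies within the scatter.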